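A few compounds are considered here, and "the series" means these few. Any claim that something is new, unique, unknown or untested is made for them only; others in the source may bear on it.

Compound 3 `O=C(NCc1ccccc1F)N1C(=O)c2ccccc2S1(=O)=O` stands at the limit of a physicochemical assay for pharmacokinetics; on this read-out lower numbers stand for a shorter-lived compound and higher numbers for a longer-lived compound: compound 3 gives > 166 h, which is a limit of the measurement rather than a number. The two compounds sharing its core sit at the same limit. Compound 1 `O=C(NCc1cccs1)N1C(=O)c2ccccc2S1(=O)=O` gives > 166 h in this assay, again a limit. Compound 2 `O=C(NCc1cccc(Br)c1)N1C(=O)c2ccccc2S1(=O)=O` gives > 166 h in this assay, also a limit. Because of the limit of > 166 h in this assay, at which 3 of the 3 values shown sit, none of the steps among these three can be read: the step from compound 1 to compound 2 is a step that the two limits leave unreadable from compound 1 to compound 2, the step from compound 1 to compound 3 is a step that the two limits leave unreadable from compound 1 to compound 3, and the step from compound 2 to compound 3 is a step that the two limits leave unreadable from compound 2 to compound 3.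

Compound 4 `COc1cccc(CNC(=O)N2C(=O)c3ccccc3S2(=O)=O)c1` differs from compound 3 in one place: 3-methoxyphenyl in place of 2-fluorophenyl on a saturated chain carbon bound to an amide-type nitrogen. Exchanges of the group on that carbon, between a thiophen-2-yl, a 3-bromophenyl and a 2-fluorophenyl, left every measured compound at the limit, so no size of step in this assay can be read from them, and the step to compound 4 cannot be predicted in size or direction beyond the scatter. The expectation is therefore that compound 4 is estimated to sit at the same limit, with the step from compound 3 to compound 4 expected to be a number no higher from compound 3 to compound 4 (the limit leaves the size open). Compound 4 is expected to give 166 h in this assay, within a range from 60 h to 166 h.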

Compound 4, half-life: > 166 h
Compound 4 was reported as a limit (the forecaster's own chance of this, stated with the estimate: 85%); the middle value sits exactly at the limit.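

Among these compounds, no step from compound 1, compound 2 or compound 3 to compound 4 can be read in this assay, because of what all four compounds share: the limit of > 166 h in this assay, at which 4 of the 4 values shown sit. The compounds shown leave open how long each one actually lasts, and whether exchanging the group on the saturated chain carbon changes the half-life at all.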